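Aryl amine in place of cyclopropylamine on the shared core

A few compounds are considered here, and "the series" means these few. Any claim that something is new, unique, unknown or untested is made for them only; others in the source may bear on it.

Measured so far:
- compound 1 `O=C1C(NC2CC2)=CC(=O)c2c1nc1n2[C@H]2OC[C@@H](O)[C@H]2OC1`, in a functional assay on MGC-803 cells (Homo sapiens) for inhibition, read by sulforhodamine B assay; on this read-out lower numbers stand for stronger inhibition and higher numbers for weaker inhibition: > 4000 nM, a limit of the assay
- compound 2 `O=C1C=C(N2CCCCC2)C(=O)c2c1nc1n2[C@H]2OC[C@@H](O)[C@H]2OC1`, in this assay: > 8000 nM, also only a limit

Compound 1 gives no number in this assay, only a limit (the limit of > 4000 nM in this assay, at which 1 of the 2 values shown sits). Compound 2 likewise sits at its own limit (the limit of > 8000 nM in this assay, at which 1 of the 2 values shown sits). For the measured compounds named here, with two limits and no numerical value, no step between measured compounds can be computed, and compound 1 cannot be ranked against compound 2.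

Compound 3 `O=C1C(Nc2cccc(F)c2)=CC(=O)c2c1nc1n2[C@H]2OC[C@@H](O)[C@H]2OC1` differs from compound 1 by 3-fluorophenyl in place of cyclopropyl on an amine nitrogen. Since the values shown are limits, the data give no direction for this change; an unchanged, limit-only result is as plausible as a gain. The step expected is an at least 1.3-fold lower number from compound 1 to compound 3 (0.12 log units; that floor lies within the scatter), toward stronger inhibition, yet with wide uncertainty. Compound 3 is estimated at 3000 nM, with a range from 400 nM to 20000 nM.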

Compound 3, half-maximal inhibitory concentration: 1470 nM
Estimate against measurement, compound 3: 2.0-fold (0.31 log units) above, and the stated range covers the measured number.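

In this assay, compound 3 is the only compound shown on the shared core that gives a number rather than a limit of the assay, at 1470 nM. Putting 3-fluorophenyl in place of cyclopropyl on the amine nitrogen gives an at least 2.7-fold lower number from compound 1 to compound 3 (0.43 log units; beyond the scatter), so an aromatic ring is accepted at this position and the change moves the read-out toward stronger inhibition by more than the usual scatter. The size of this step is only a floor, as one end of it is a limit: the limit of > 4000 nM in this assay, at which 1 of the 3 values shown sits.

Whether the fluorine contributes to the gain or the aromatic ring alone accounts for it remains open, and a plain phenyl on the same nitrogen would separate the two. Also open, as far as these compounds go, is whether a benzyl group on that nitrogen, with its ring set one carbon further out, would keep the gain.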